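Pyrazole urea series: the step from compound 3 to compound 4

The compounds below may be only part of what the source reports. "The series", "measured", "known", "first", "only" and "open" are said of these compounds alone.

Measured so far in this set:
compound 1, `Cc1cnn(C(=O)NCc2ccc(OCc3ccccc3)cc2)c1`: 1200 nM
compound 2, `N#Cc1cnn(C(=O)N2CCCN(Cc3ccc(OCc4ccccc4)cc3)CC2)c1`: < 10 nM
compound 3, `Cc1cnn(C(=O)N2CCN(C(c3ccc(OCc4ccccc4)cc3)c3ccc(OCc4ccccc4)cc3)CC2)c1`: > 100000 nM

In an assay on membranes from brain for binding affinity to Fatty-acid amide hydrolase 1 (Mus musculus), read by fluorescence, with stated times of 1 h and 30 min (on this read-out lower numbers stand for stronger inhibition and higher numbers for weaker inhibition), compound 1 gives 1200 nM. For compound 2 this assay reports only a limit, < 10 nM, namely (the limit of < 10 nM in this assay, at which 1 of the 3 values shown sits). For compound 3 this assay likewise reports only a limit, > 100000 nM, namely (the limit of > 100000 nM in this assay, at which 1 of the 3 values shown sits). Compound 3 therefore stands at the weak end of what this assay can report, and no number is known for it; of the three values shown, two are limits and only compound 1 has a number.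

Compound 4, `O=C(N1CCN(C(c2ccc(OCc3ccccc3)cc2)c2ccc(OCc3ccccc3)cc2)CC1)n1cccn1`, differs from compound 3 in one place: hydrogen in place of methyl on an aromatic carbon, or, read one bond further out, 4-methyl-1H-pyrazol-1-yl to 1H-pyrazol-1-yl. Among the measured compounds shown here, no two measured compounds differ only in this way, so no measured step gives the size of this change. With compound 3 resting at a limit, the expected step of a number no higher from compound 3 to compound 4 (the limit leaves the size open) is none beyond the scatter, in either direction. Compound 4 is therefore expected to give about 100000 nM, within 20000 nM to 400000 nM, with a fair chance that this assay again reports only a limit.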

Compound 4, half-maximal inhibitory concentration: > 100000 nM
Compound 4: a limit, no number; the forecaster's own chance of this, stated with the estimate: 70%; the middle value lies on the limit itself.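

In this assay compound 4 gives > 100000 nM, which is a limit and not a number. Among the compounds shown here, compound 3 gives > 100000 nM, also a limit, so no step to compound 4 can be read. The compounds shown leave open whether the change from 4-methyl-1H-pyrazol-1-yl to 1H-pyrazol-1-yl alters inhibition on this shared core, and by how much.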